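The compounds below may be only part of what the source reports. "The series", "measured", "known", "first", "only" and "open" are said of these compounds alone.

Three compounds sharing one core were measured in a functional assay on HEK293 cells for agonist activity at Glucose-dependent insulinotropic receptor (Homo sapiens), read by HTRF and cAMP accumulation, with a stated time of 30 min; a higher number here means that more compound is needed for the effect, a lower number that less compound is needed:
compound 1 `CCNC(=O)c1cc(F)c(-c2cc3nnn(C4CCN(C(=O)OC(C)C)CC4)c3cn2)cc1F` gives 37 nM;
compound 2 `CC(C)NC(=O)c1cc(F)c(-c2cc3nnn(C4CCN(C(=O)OC(C)C)CC4)c3cn2)cc1F` gives 33 nM;
compound 3 `CC(C)OC(=O)N1CCC(n2nnc3cc(-c4cc(F)c(C(=O)N5CCC5)cc4F)ncc32)CC1` gives 61 nM.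

Compound 3 stands at the upper end of these three numbers, yet its gaps to the other two, a 1.6-fold higher number from compound 1 to compound 3 (0.22 log units; within the scatter) and a 1.8-fold higher number from compound 2 to compound 3 (0.27 log units; within the scatter), both lie within the scatter. Compound 4 `CC(C)OC(=O)N1CCC(n2nnc3cc(-c4cc(F)c(C(=O)N5CCCC5)cc4F)ncc32)CC1` differs from compound 3 by one change on the carbonyl carbon: pyrrolidin-1-yl in place of azetidin-1-yl on a carbonyl carbon. The measured steps that bear on this change all alter the group on that same carbonyl carbon: a 1.1-fold lower number from compound 1 to compound 2 (0.05 log units; within the scatter), a 1.6-fold higher number from compound 1 to compound 3 (0.22 log units; within the scatter) and a 1.8-fold higher number from compound 2 to compound 3 (0.27 log units; within the scatter), none of them beyond the scatter. No step beyond the scatter is therefore expected in this assay for compound 4, that is a 1.0-fold lower number from compound 3 to compound 4 (0.01 log units; within the scatter). Compound 4 is estimated at 60 nM, with a range from 25 nM to 150 nM.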

Compound 4, half-maximal effective concentration: 65 nM
The estimate for compound 4 lay 1.1-fold (0.03 log units) below the measured number; the measured number falls inside the stated range.
By their numbers in this assay, from the lowest: compounds 2, 1, 3 and 4 (each within the scatter of the next).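

In this assay the carbonyl carbon now carries a second ring size, and the step between the two rings is small: a 1.1-fold higher number from compound 3 to compound 4 (0.03 log units; within the scatter). The steps from the open-chain groups, a 1.8-fold higher number from compound 1 to compound 4 (0.24 log units; within the scatter) and a 2.0-fold higher number from compound 2 to compound 4 (0.29 log units; within the scatter), show that ethylamino, isopropylamino, azetidin-1-yl and pyrrolidin-1-yl all sit on this carbon with no step beyond the scatter. No measurement shown offers an explanation for this flat response.

From the compounds shown here alone, whether piperidin-1-yl, morpholin-4-yl or a chain ending in a carboxylic acid would behave the same on this carbonyl carbon remains open.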